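Aryloxy swap on the shared core, compound 1 to compound 4

The source may report more compounds than this note shows. Statements on the series, on what has been measured and on what is new or still open speak of the compounds shown alone.

The series is followed in a functional assay on RXF 393 cells (Homo sapiens) for inhibition, read by sulforhodamine B assay, with a stated time of 48 h; on this read-out lower numbers stand for stronger inhibition of growth and higher numbers for weaker inhibition of growth. For the measured compounds named here, compound 1 `Nc1cc(N)c2nc(-c3ccccc3)c(Oc3ccc(Cl)c(Cl)c3)nc2c1` is the only member with a number on this read-out: in this assay compound 1 gives 58900 nM. Compound 2 `CCOC(=O)[C@H](CCC(=O)O)NC(=O)c1ccc(CNc2nc3cc(N)cc(N)c3nc2-c2ccccc2)cc1` returns only a limit of the assay, < 100000 nM in this assay. Compound 3 `COc1ccc(CNc2nc3cc(N)cc(N)c3nc2-c2ccccc2)cc1OC` likewise returns a limit, < 100000 nM in this assay. Where compound 1 stands is therefore told by a single number, with the two other values sitting at the limit of < 100000 nM in this assay, at which 2 of the 3 values shown sit. Going by the values given here, no step between measured compounds that differ in one place exists in the set.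

Compound 4 `Nc1cc(N)c2nc(-c3ccccc3)c(Oc3ccc(F)cc3)nc2c1` differs from compound 1 by 4-fluorophenyl in place of 3,4-dichlorophenyl on an oxygen on an aromatic ring; read one bond further out, 3,4-dichlorophenoxy gives way to 4-fluorophenoxy, and the shared core stays as it is. Among the compounds with values here, nothing measured in the set speaks to this change, so the expected step rests on the single number of compound 1 alone. The expectation is a modest step toward weaker inhibition of growth, of the size a 1.4-fold higher number from compound 1 to compound 4 (0.13 log units; within the scatter), which may still lie within the usual scatter. Compound 4 is estimated at 80000 nM in this assay, with a range from 30000 nM to 150000 nM, and a real chance that the assay reports only a limit.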

Compound 4, concentration for total growth inhibition: < 100000 nM
Compound 4: a limit, no number; the forecaster's own chance of this, stated with the estimate: 40%; the middle value is on the limit's open side.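

In this assay compound 4 returns < 100000 nM, a limit of the assay and not a number. For the compounds shown here, no step from compound 1 to compound 4 can therefore be read. The set now rests largely on that limit: the limit of < 100000 nM in this assay, at which 3 of the 4 values shown sit.

The compounds shown leave open whether 4-fluorophenyl in place of 3,4-dichlorophenyl on an oxygen on an aromatic ring changes inhibition of growth at all, and in which direction.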